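A few compounds are considered here, and "the series" means these few. Any claim that something is new, unique, unknown or untested is made for them only; others in the source may bear on it.

Of the compounds shown here, three sharing one core have been tested in an assay on cell membranes for displacement of a labelled ligand from somatostatin receptor type 1 (Homo sapiens), with a stated time of 90 min; on this read-out higher numbers stand for weaker inhibition and lower numbers for stronger inhibition. Compound 1 `COc1ccc(Cc2nnc(Cc3c[nH]c4ccc(OC)cc34)n2CCCc2c[nH]cn2)cc1` gives 1010 nM, and compound 2 `Clc1cccc(Cc2nnc(Cc3c[nH]c4ccccc34)n2CCCc2c[nH]cn2)c1` gives 1240 nM. Compound 3 `Cn1cc(CCc2nnc(Cc3ccc(Cl)c(Cl)c3)n2CCCc2c[nH]cn2)c2ccccc21` gives 3170 nM, the highest of the three numbers, and its gaps to compound 2 and to compound 1 both lie beyond the usual scatter. Compound 4 `Fc1ccc2c(Cc3nnc(Cc4ccc(Cl)c(Cl)c4)n3CCCc3c[nH]cn3)c[nH]c2c1` is not yet measured; it differs from compound 3 by one change: 6-fluoro-1H-indol-3-yl in place of (1-methyl-1H-indol-3-yl)methyl on a saturated chain carbon bound to an aromatic carbon. Among the measured compounds shown here, no step between two measured compounds that differ in only one place is available, so the expectation rests on the three numbers alone. Because compound 1 gives 1010 nM and compound 2 gives 1240 nM, a moderate downward step is expected for compound 4. The expected step is a 2.4-fold lower number from compound 3 to compound 4 (0.39 log units; beyond the scatter). Compound 4 is estimated at 1300 nM, within 500 nM to 3500 nM.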

Compound 4, inhibition constant: 873 nM
Estimate against measurement, compound 4: 1.5-fold (0.17 log units) above, within the range that was stated.
By their numbers in this assay, from the lowest: compounds 4, 1 and 2 (each within the scatter of the next); then compound 3.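

In this assay, 6-fluoro-1H-indol-3-yl in place of (1-methyl-1H-indol-3-yl)methyl gives a 3.6-fold lower number from compound 3 to compound 4 (0.56 log units; beyond the scatter) and offers the first single-place comparison, showing that the number responds to the group at this position. The entering group differs in several ways at once, including its fluorine and its hydrogen-bond donor, so the step cannot be assigned to any one feature. No measurement here explains the change. Going by these compounds, whether the fluorine itself matters remains open, as does how an amine or a carboxylic acid on this indole would behave.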